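Swapping Iodo for Methoxy in a Growth Inhibitor

The source may hold more compounds than are shown below. What is called first, only, known or untested is meant among the compounds shown, and "the series" means these compounds.

Measured so far in a functional assay on CAKI-1 cells (Homo sapiens) for inhibition; a higher number here means a weaker inhibitor of growth, a lower number a stronger inhibitor of growth:
compound 1 `NC(=O)c1cc(Cl)ccc1NC(=O)COc1ccccc1` gives 4180 nM
compound 2 `NC(=O)c1cc(I)ccc1NC(=O)COc1ccccc1` gives 519 nM

Compound 2 holds the lower of these two numbers, making it the stronger inhibitor of growth so far. Compound 3 `COc1ccc(NC(=O)COc2ccccc2)c(C(N)=O)c1` is not yet measured and differs from it in one group: methoxy in place of iodo on an aromatic carbon. Among the compounds with values here, the only measured step at this place, iodo in place of chloro, was an 8.1-fold lower number from compound 1 to compound 2 (0.91 log units; beyond the scatter) and shows that a swap here can matter. Within the data shown here, no methoxy compound has been measured, so this guide is indirect. A step of similar size back towards weaker inhibition seems likely. The expected change is a 4.8-fold higher number from compound 2 to compound 3 (0.68 log units; beyond the scatter) in this assay. Compound 3 is estimated at 2500 nM, with an expected range from 600 nM to 10000 nM.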

Compound 3, concentration for 50% growth inhibition: 721 nM
Beside the measured number, compound 3's estimate is 3.5-fold (0.54 log units) above it, and the stated range covers the measured number.
By their numbers in this assay, from the lowest: compounds 2 and 3 (each within the scatter of the next); then compound 1.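

Methoxy in place of iodo gives a 1.4-fold higher number from compound 2 to compound 3 (0.14 log units; within the scatter), so compound 2 and compound 3 cannot be told apart in this assay. Methoxy in place of chloro gives a 5.8-fold lower number from compound 1 to compound 3 (0.76 log units; beyond the scatter), which shows that the drop seen with iodo is not unique to iodo: two very different groups at this position both give lower numbers than chloro. Nothing available explains why these two groups match.

On these data alone, whether an amine or a carboxylic acid at this position would match compound 3 stays open. So does whether a longer chain, such as ethoxy, would do the same.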